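Methoxy removal on the aryl ketone series

The compounds below may be only part of what the source reports. "The series", "measured", "known", "first", "only" and "open" are said of these compounds alone.

Measured so far in a functional assay on CCRF-CEM cells (Homo sapiens) for antiproliferative activity; a higher number here means a weaker inhibitor, a lower number a stronger inhibitor:
compound 1, `COc1cc(C(=O)c2ccc3c(ccn3C)c2)cc(OC)c1OC`, gives 18 nM
compound 2, `COc1cc(OC)cc(C(=O)c2ccc3c(ccn3C)c2)c1`, gives 1690 nM
compound 3, `COc1ccc(C(=O)c2ccc3c(ccn3C)c2)c(OC)c1`, gives 102 nM

All three share the same ketone-linked bicyclic part; what changes is the methoxy pattern on the six-membered aromatic ring of carbon only. The difference between the core of compound 1 and the core of compound 3 is not broken down here. From compound 1 to compound 2 the change is hydrogen in place of methoxy on an aromatic carbon, and it gives a 94-fold higher number from compound 1 to compound 2 (1.97 log units; beyond the scatter). Compound 4, `COc1ccc(C(=O)c2ccc3c(ccn3C)c2)cc1`, is not yet measured; it differs from compound 3 by hydrogen in place of methoxy on an aromatic carbon. This is the same kind of change as from compound 1 to compound 2, but not the same: in compound 1 the leaving methoxy sits ortho to two methoxy groups and para to a large group, whereas in compound 3 it sits ortho to a large group and meta to a methoxy group. Compound 3 is weaker than compound 1, and compound 2 weaker than compound 3. For compound 4 a loss is expected, smaller than the earlier step, because a 94-fold higher number from compound 1 to compound 2 (1.97 log units; beyond the scatter) concerns a methoxy ortho to two methoxy groups and para to a large group, a surrounding compound 3 does not share; the expected step is a 9.8-fold higher number from compound 3 to compound 4 (0.99 log units; beyond the scatter). Compound 4 is estimated at 1000 nM, most likely between 250 nM and 5000 nM.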

Compound 4, half-maximal inhibitory concentration: 1130 nM
Estimate against measurement, compound 4: 1.1-fold (0.05 log units) below; measured number inside the range.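

In this assay, hydrogen in place of methoxy raises the number on both cores, with an 11-fold higher number from compound 3 to compound 4 (1.04 log units; beyond the scatter) beside the earlier 94-fold higher number from compound 1 to compound 2 (1.97 log units; beyond the scatter). The direction of the change carries from one core to the other, but its size does not: the same change on two cores in this assay, a 94-fold higher number (1.97 log units; beyond the scatter) from compound 1 to compound 2 and an 11-fold higher number (1.04 log units; beyond the scatter) from compound 3 to compound 4, 8.5-fold (0.93 log units) apart, beyond the scatter of two such steps

These two pairs show neither why the size differs nor what size to expect on a further core, and they support only the direction, and only for the compounds shown. The compounds shown leave open whether another group at the place of the leaving methoxy in compound 3, ortho to a large group, such as a hydroxyl, an ethoxy or an amine, would keep the number near that of compound 3, 102 nM, rather than give the loss seen with hydrogen. Also open, on these data alone, is what happens when the carbonyl linking the two parts is replaced, for example by a methylene, as all four compounds keep that carbonyl.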